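A few compounds are considered here, and "the series" means these few. Any claim that something is new, unique, unknown or untested is made for them only; others in the source may bear on it.

In an ADME assay on MDCKII-LE cells (Canis lupus familiaris) for permeability, read by transwell migration, in the apical to basolateral direction (a lower number here means that the compound crosses the layer more slowly, a higher number that the compound crosses the layer faster), compound 2 `NC(=O)[C@@H](CCC(F)(F)F)N(CC1CCOCC1)S(=O)(=O)c1ccc(Cl)cc1` gives 26.3 10^-6 cm/s and stands level, within the scatter, with compound 1 `NC(=O)[C@@H](CCC(F)(F)F)N(C[C@H]1CCCOC1)S(=O)(=O)c1ccc(Cl)cc1` at 18.2 10^-6 cm/s in the same measurement. Within the data shown here, the only measured step is a 1.4-fold higher number from compound 1 to compound 2 (0.16 log units; within the scatter) and it replaces oxan-3-yl with oxan-4-yl while the rest of the structure stays the same. Compound 3 `NC(=O)[C@@H](CCC(F)(F)F)N(C[C@@H]1CCCO1)S(=O)(=O)c1ccc(Cl)cc1` has not yet been measured. It carries oxolan-2-yl in place of oxan-4-yl on a saturated chain carbon bound to a sulfonamide nitrogen and thereby goes from a six-membered to a five-membered ring. Among the measured compounds shown here, neither measured compound has a five-membered ring, so the one measured step bears on this change only indirectly. With just a 1.4-fold higher number from compound 1 to compound 2 (0.16 log units; within the scatter) as a guide, no shift beyond the scatter is expected in this assay for this exchange. The estimated step is a 1.3-fold lower number from compound 2 to compound 3 (0.12 log units; within the scatter) and it is expected to stay within the scatter, with only a slight lean towards a lower number. Compound 3 is estimated at 20 10^-6 cm/s with an expected range from 11 10^-6 cm/s to 36 10^-6 cm/s in this measurement.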

Compound 3, apparent permeability: 22.4 10^-6 cm/s
Beside the measured number, compound 3's estimate is 1.1-fold (0.05 log units) below it; low and high end bracket the measured number.
By their numbers in this assay, from the lowest: compounds 1, 3 and 2 (each within the scatter of the next).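

In this assay, exchanging the six-membered oxan-4-yl for the five-membered oxolan-2-yl on a saturated chain carbon bound to a sulfonamide nitrogen gives a 1.2-fold lower number from compound 2 to compound 3 (0.07 log units; within the scatter). This exchange adds a change of ring size to the change of ring attachment already seen between compound 1 and compound 2. Set against oxan-3-yl, the same five-membered ring gives a 1.2-fold higher number from compound 1 to compound 3 (0.09 log units; within the scatter) and so also stays within the scatter, which leaves all three compounds level in this assay across these three rings, each with one oxygen as its only hetero atom. No measurement on hand offers an explanation for this levelness.

All three compounds keep a saturated ring with one oxygen at this place, so the result says nothing about how a ring carrying an amine, such as piperidin-4-yl, an all-carbon cyclohexyl ring or a carboxylic acid would read in this assay. Going by these compounds, the mirror-image form of the oxolan-2-yl group and the oxolan-3-yl group also remain open, as does whether the levelness would hold on a core other than that of compound 1.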